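The source may hold more compounds than are shown below. What is called first, only, known or untested is meant among the compounds shown, and "the series" means these compounds.

In an assay on HEK293 cells for binding affinity to Urotensin-2 receptor (Homo sapiens), read by radioligand binding (on this read-out lower numbers stand for stronger inhibition and higher numbers for weaker inhibition), compound 1 `CN(C)CCCOc1ccc(CN2CC[C@H](NC(=O)c3cc(Cl)cc(Cl)c3)C2)cc1` gives 2000 nM.
In this assay compound 2 `CN(C)CCCOc1ccc(CN2CC[C@H](NC(=O)c3ccc(C(F)(F)F)cc3)C2)cc1` is reported only as a limit, < 10000 nM.
In this assay compound 3 `CN(C)CCCOc1ccc(CN2CC[C@H](NC(=O)c3ccc(-c4ccccc4)cc3)C2)cc1` is likewise reported only as a limit, < 10000 nM.

Compound 2 therefore stands at a limit and not at a number, and it shares that position with one other value, as the limit of < 10000 nM in this assay, at which 2 of the 3 values shown sit, shows. This leaves the two steps that touch it without readable size: a step that the limit leaves unreadable from compound 1 to compound 2 and a step that the two limits leave unreadable from compound 2 to compound 3. Going by the values given here, compound 1 supplies the only numeric value, and it sits at the weaker end of the readout.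

Compound 4 `CN(C)CCCOc1ccc(CN2CC[C@H](NC(=O)c3ccc4ccccc4c3)C2)cc1` arises from compound 2 by naphthalen-2-yl in place of 4-(trifluoromethyl)phenyl on a carbonyl carbon. Among the compounds with values here, no measured step bears on this change with a readable size, since both steps involving compound 2 run into a limit. The estimate for compound 4 in this assay rests only on the number from compound 1 and on the limits around it, and a step that the limit leaves unreadable from compound 2 to compound 4 is expected, in the direction of modest strengthening, though a reported limit rather than a number remains possible. Compound 4 is expected to give about 3000 nM, in a range from 700 nM to 10000 nM.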

Compound 4, inhibition constant: < 10000 nM
Compound 4: no number, only a limit (the forecaster's own chance of this, stated with the estimate: 40%); the middle value is on the limit's open side.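

In this assay compound 4 is reported only as a limit, < 10000 nM. No new step can be read from this result, as neither step from compound 1 or compound 2 to compound 4 has a readable size: the limit of < 10000 nM in this assay, at which 3 of the 4 values shown sit. As far as these compounds go, whether compound 2, compound 3 and compound 4 differ from one another or from compound 1 in this assay remains open.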